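From neopentyl to cyclopentylmethyl in the series

The source may hold more compounds than are shown below. What is called first, only, known or untested is meant among the compounds shown, and "the series" means these compounds.

In a functional assay (strain AB) with Danio rerio as the target, read by microscopy, with a stated time of 1 h (on this read-out higher numbers stand for an effect only at larger amounts of compound and lower numbers for an effect already at smaller amounts), compound 1 `CC(C)(C)OC(=O)CCC[N+]1(C)CCc2c(sc(NC(=O)Nc3ccc(Cl)cc3)c2C(N)=O)C1` gives 250 nM, compound 2 `CC(C)[N+]1(C)CCc2c(sc(NC(=O)Nc3ccc(Cl)cc3)c2C(N)=O)C1` gives 960 nM and compound 3 `CC(C)(C)C[N+]1(C)CCc2c(sc(NC(=O)Nc3ccc(Cl)cc3)c2C(N)=O)C1` gives 290 nM. Compound 3 cannot be separated from its nearest neighbour, with a 1.2-fold higher number from compound 1 to compound 3 (0.06 log units; within the scatter). The gap on the other side is real, at a 3.3-fold lower number from compound 2 to compound 3 (0.52 log units; beyond the scatter).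

Compound 4 `C[N+]1(CC2CCCC2)CCc2c(sc(NC(=O)Nc3ccc(Cl)cc3)c2C(N)=O)C1` carries cyclopentyl in place of tert-butyl on a saturated chain carbon bound to an amine nitrogen in a ring, (cyclopentyl in place of tert-butyl on a saturated chain carbon bound to an amine nitrogen in a ring). The same difference, cut one bond further out, reads neopentyl to cyclopentylmethyl.

Two further observations bear on this change. Both steps beyond the scatter involve the isopropyl of compound 2, namely a 3.8-fold higher number from compound 1 to compound 2 (0.58 log units; beyond the scatter) and the neopentyl step already given. Among the three measured compounds, only compound 2 stands apart, and the very different groups of compound 1 and compound 3 give values within the scatter of each other. Among the measured compounds shown here, no measured compound carries a ring in this group, so the data do not test that feature directly.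

The step expected in this assay is a 1.1-fold lower number from compound 3 to compound 4 (0.03 log units; within the scatter), which means none beyond the scatter. For compound 4 the estimated value is 270 nM, with an expected range of 120 nM to 620 nM.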

Compound 4, half-maximal effective concentration: 200 nM
Compound 4: the middle estimate sits 1.4-fold (0.13 log units) above what was measured; the measured number falls inside the stated range.
By their numbers in this assay, from the lowest: compounds 4, 1 and 3 (each within the scatter of the next); then compound 2.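

Cyclopentyl in place of tert-butyl introduces the only ring among these groups and gives a 1.5-fold lower number from compound 3 to compound 4 (0.16 log units; within the scatter) in this assay, so a five-membered carbon ring at this position cannot be told apart from the open neopentyl group. Cyclopentyl in place of 2-(tert-butoxycarbonyl)ethyl gives a 1.3-fold lower number from compound 1 to compound 4 (0.10 log units; within the scatter), which places three differently built groups within the scatter of one another, while cyclopentylmethyl in place of isopropyl gives a 4.8-fold lower number from compound 2 to compound 4 (0.68 log units; beyond the scatter) and confirms that, among the four compounds, isopropyl alone stands apart. No supporting measurement bears on why these groups group together or why isopropyl differs from them.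

Still open, from the compounds shown here alone, is whether the flat response extends to a larger ring such as cyclohexylmethyl, to an aromatic group such as benzyl, or to a chain ending in a carboxylic acid or an amine rather than the tert-butyl ester. Also open, going by these compounds, is whether cyclopentyl placed directly on the amine nitrogen in a ring would fall with isopropyl or with cyclopentylmethyl.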